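The compounds below may be only part of what the source reports. "The series", "measured", "known", "first", "only" and "open" are said of these compounds alone.

Working notes on the series, read in a functional assay on HCT-116 cells (Homo sapiens) for cytotoxicity, read by MTT assay; a higher number here means a weaker inhibitor, a lower number a stronger inhibitor. Compound 1 `CSc1nc(NCc2ccc(C(=O)Nc3ccccc3N)cc2)n[nH]1` gives 600 nM, compound 2 `Nc1ccccc1NC(=O)c1ccc(CNc2nc3ccccc3[nH]2)cc1` gives 300 nM, and compound 3 `Nc1ccccc1NC(=O)c1ccc(CSc2ncc[nH]2)cc1` gives 5000 nM. Compound 3 has the highest number of the three, and its gaps to the other two lie beyond the scatter.

The next entry is compound 4 `Nc1ccccc1NC(=O)c1ccc(CNc2ncc(Br)s2)cc1`. (5-bromo-1,3-thiazol-2-yl)amino in place of (1H-imidazol-2-yl)sulfanyl on a saturated chain carbon bound to an aromatic carbon In words, this is (5-bromo-1,3-thiazol-2-yl)amino in place of (1H-imidazol-2-yl)sulfanyl on a saturated chain carbon bound to an aromatic carbon.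

Within the data shown here, two measured steps bear on this. The closer one is an 8.3-fold higher number from compound 1 to compound 3 (0.92 log units; beyond the scatter), which introduces (1H-imidazol-2-yl)sulfanyl, the group that compound 4 gives up. The other is a 2.0-fold lower number from compound 1 to compound 2 (0.30 log units; within the scatter), a change of ring on the amine nitrogen. Among the measured compounds shown here, no measured compound carries the 5-bromo-1,3-thiazol-2-yl group, so its own contribution remains open. A modest move to a lower number is therefore expected, roughly reversing the first step.

The expected step is a 6.3-fold lower number from compound 3 to compound 4 (0.80 log units; beyond the scatter). For compound 4 the estimated value is 800 nM, with an expected range of 250 nM to 3000 nM.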

Compound 4, half-maximal inhibitory concentration: 400 nM
The estimate for compound 4 lay 2.0-fold (0.30 log units) above the measured number; measured number inside the range.
By their numbers in this assay, from the lowest: compounds 2, 4 and 1 (each within the scatter of the next); then compound 3.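

In this assay, the change on the saturated chain carbon bound to an aromatic carbon gives a 13-fold lower number from compound 3 to compound 4 (1.10 log units; beyond the scatter), so this position can respond strongly, and a bromine-bearing ring is compatible with a number in the range of the other amine-linked compounds. The other two new steps, a 1.3-fold higher number from compound 2 to compound 4 (0.12 log units; within the scatter) and a 1.5-fold lower number from compound 1 to compound 4 (0.18 log units; within the scatter), show that three different rings on the amine nitrogen stay within the scatter of one another, leaving compound 3, the only sulfanyl-linked entry, apart from the rest. No measurement is available that explains these differences.

Since the link atom and the ring change together from compound 3 to compound 4, the compounds shown do not assign the gap to either one. A (1H-imidazol-2-yl)amino group at this position would separate those two contributions, and an unsubstituted 1,3-thiazol-2-yl on the amine nitrogen would isolate the contribution of the bromine.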